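The source may report more compounds than this note shows. Statements on the series, on what has been measured and on what is new or still open speak of the compounds shown alone.

For the measured compounds named here, in a toxicity assay on THP-1 cells (Homo sapiens) for inhibition (a lower number here means that less compound is tolerated, a higher number that more compound is tolerated), only compound 2 `Cn1c(-c2ccc(Br)cc2)cnc1NC(=O)c1ccc(F)cc1` has a true number among the three compounds tested so far, at 46000 nM. Compound 1 `Cn1c(-c2ccccc2F)cnc1NC(=O)c1ccc(F)cc1` reports only a limit, > 100000 nM. Compound 3 `Cc1ccccc1-c1cnc(NC(=O)c2ccc(F)cc2)n1C` also reports only a limit, > 50000 nM. Those limits still allow two comparisons: an at least 2.1-fold lower number from compound 1 to compound 2 (0.33 log units; beyond the scatter), which lies beyond the scatter, and an at least 1.0-fold higher number from compound 2 to compound 3 (0.03 log units; that floor lies within the scatter), whose floor lies within it.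

Compound 4 `Cn1c(-c2ccc([N+](=O)[O-])cc2)cnc1NC(=O)c1ccc(F)cc1` keeps the frame of compound 2 but carries nitro in place of bromo on an aromatic carbon, para to a large group (nitro in place of bromo on an aromatic carbon). Going by the values given here, no measured step makes this exact exchange. The two readable steps are the nearest guide, as both alter the same aromatic group, but neither fixes a size or direction for this change. The expected outcome for a 1.1-fold higher number from compound 2 to compound 4 (0.04 log units; within the scatter) is therefore no step beyond the scatter, in either direction. The estimate for compound 4 is 50000 nM, with an expected range from 20000 nM to 120000 nM.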

Compound 4, half-maximal cytotoxic concentration: > 50000 nM
Compound 4 was reported as a limit; the forecaster's own chance of this, stated with the estimate: 40%; the middle value lies on the limit itself.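

In this assay compound 4 reports only a limit, > 50000 nM. Exchanging bromo for nitro at this place on the aromatic ring therefore gives an at least 1.0-fold higher number from compound 2 to compound 4 (0.03 log units; that floor lies within the scatter), so a larger group with two hydrogen-bond acceptors leaves no sign of a lower number, although the real size of the step cannot be read. Compound 2 remains the only compound with a true number, and compound 4 joins a value already seen in this series: the limit of > 50000 nM in this assay, at which 2 of the 4 values shown sit.

Going by these compounds, without a true number for compound 4, it stays open whether nitro and bromo differ at all at this place. On these data alone, it also stays open whether an amine, a carboxylic acid or a longer chain in the same place would bring the number down to a readable value.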